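This account rests on a few compounds, and the source may have more. Where it says the series, first, only, none or still open, it means among the compounds named here.

Working notes on the series. Among the measured compounds shown here, in a physicochemical assay for acid dissociation, compound 2 `COc1ccc(-c2c(C)nc3c(NCc4ccc(C(N)=O)cc4)nc(C)cn23)cc1OC` gives 5, the higher of the two numbers so far; compound 1 `COc1ccc(-c2c(C)nn3c(NCc4cccnc4)nc(C)cc23)cc1OC` gives 2.8, a gap beyond the usual scatter, and the two share no single-point step. Compound 3 `COc1ccc(-c2c(C)nc3c(NCc4cccnc4)nc(C)cn23)cc1OC` is the next member: pyridin-3-yl in place of 4-carbamoylphenyl on a saturated chain carbon bound to a nitrogen on an aromatic ring. For the measured compounds named here, no measured step covers this change on the core of compound 2, so from compound 2 to compound 3 a small shift in this assay is expected, a number 0.30 log units lower from compound 2 to compound 3 (within the scatter), downward if anything and possibly within scatter. Compound 3 is expected to give about 4.7, between 3.6 and 5.5.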

Compound 3, acid dissociation constant: 5.3
Estimate against measurement, compound 3: 0.60 log units below; low and high end bracket the measured number.
By their numbers in this assay, from the lowest: compound 1; then compounds 2 and 3 (each within the scatter of the next).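

Among the compounds shown here, the first single-point step in this assay is a number 0.30 log units higher from compound 2 to compound 3 (within the scatter) with pyridin-3-yl in place of 4-carbamoylphenyl on a saturated chain carbon bound to a nitrogen on an aromatic ring. On the core of compound 2, this exchange of a carbon-only aromatic ring for one with a hetero atom, with the carbamoyl group gone, stays within the scatter. Nothing at hand bears on the origin of this result. Open, as far as these compounds go, are an amine or a carboxylic acid at this place, and the same exchange on the core of compound 1.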